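The source may report more compounds than this note shows. Statements on the series, on what has been measured and on what is new or still open speak of the compounds shown alone.

In a functional assay on CWR22R cells (Homo sapiens) for antiproliferative activity, read by propidium iodide staining, with a stated time of 96 h (a lower number here means a stronger inhibitor, a higher number a weaker inhibitor), compound 1 (`CC(O)(COc1ccc(S(F)(F)(F)(F)F)cc1)C(=O)Nc1ccc([N+](=O)[O-])c(C(F)(F)F)c1`) gives 14100 nM and compound 2 (`CC(O)(CS(=O)(=O)c1ccccc1C(F)(F)F)C(=O)Nc1ccc(S(F)(F)(F)(F)F)cc1`) gives 17400 nM while compound 3 (`CC1(C)C(=O)N(c2ccc([N+](=O)[O-])c(C(F)(F)F)c2)C(=S)N1c1cccc(S(F)(F)(F)(F)F)c1`) gives 100000 nM as the highest number of the three. That makes compound 3 the weakest inhibitor so far, beyond the scatter from both of the others. Compound 4 (`CC1(C)C(=O)N(c2ccc(C#N)c(C(F)(F)F)c2)C(=S)N1c1cccc(S(F)(F)(F)(F)F)c1`) has not been measured yet and differs from compound 3 by cyano in place of nitro on an aromatic carbon with the rest of the structure unchanged. Among the measured compounds shown here, no measured pair shows this exchange, so any forecast is loose. The expected change in this assay is a moderate fall in the number, estimated as a 3.3-fold lower number from compound 3 to compound 4 (0.52 log units; beyond the scatter) and so only somewhat beyond the scatter. For compound 4 the estimated value is 30000 nM with an expected range from 8000 nM to 100000 nM as a rough guess.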

Compound 4, half-maximal inhibitory concentration: 100000 nM
Compound 4: middle estimate off by 3.3-fold (0.52 log units), on the low side, and the stated range covers the measured number.
By their numbers in this assay, from the lowest: compounds 1 and 2 (each within the scatter of the next); then compounds 3 and 4 (each within the scatter of the next).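

In this assay, among the compounds shown here, putting cyano in place of nitro on this aromatic carbon, ortho to a trifluoromethyl group, shows no change at the digits printed from compound 3 to compound 4 (within the scatter) and gives the first direct reading of this exchange. On this shared core, the smaller cyano group gives no measurable gain over nitro. Nothing available here bears on the reason for this result. From the compounds shown here alone, whether another group at this place, such as an amine or a carboxylic acid, would lower the number remains open. Going by these compounds, it is also open whether the same exchange would behave alike on the core of compound 1, which also carries nitro.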